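The source may hold more compounds than are shown below. What is called first, only, known or untested is meant among the compounds shown, and "the series" means these compounds.

Among the compounds with values here, in a functional assay on LNCaP cells (Homo sapiens) for cytotoxicity, read by MTT assay (a lower number here means a stronger inhibitor, a higher number a weaker inhibitor), two compounds built on a shared core have numbers so far. Compound 1 `COc1ccc2cc([C@H](C)c3nnc(SCc4ccccc4)n3-c3ccc(Cl)cc3)ccc2c1` gives 50400 nM, and compound 2 `COc1ccc2cc([C@H](C)c3nnc(SCc4c(Cl)cccc4Cl)n3-c3cccc(Cl)c3)ccc2c1` gives 73700 nM. These two values lie within the usual scatter of each other, so compound 2 cannot be ranked apart from compound 1. The two compounds differ in more than one place, and no single structural change can be read from them.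

Compound 3 `COc1ccc2cc([C@H](C)c3nnc(SCc4c(Cl)cccc4Cl)n3-c3ccc(Cl)cc3)ccc2c1` has not yet been measured. It keeps the (2,6-dichlorobenzyl)sulfanyl group of compound 2 but carries 4-chlorophenyl in place of 3-chlorophenyl on an aromatic nitrogen. The 4-chlorophenyl group is also present in compound 1, so compound 3 shares one feature with each measured compound. With compound 1 at 50400 nM and compound 2 at 73700 nM, the measured values offer no sign of a large shift, and no change beyond the scatter is expected in this assay. The expected move is small: a 1.2-fold lower number from compound 2 to compound 3 (0.09 log units; within the scatter). For compound 3 the estimated value is 60000 nM, with an expected range of 30000 nM to 100000 nM.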

Compound 3, half-maximal inhibitory concentration: > 400000 nM
Compound 3: no number, only a limit; the forecaster's own chance of this, stated with the estimate: 15%; middle value at least 6.6-fold (0.82 log units) away from the limit.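

In this assay, with the (2,6-dichlorobenzyl)sulfanyl group held in place, 4-chlorophenyl in place of 3-chlorophenyl on the aromatic nitrogen gives an at least 5.4-fold higher number from compound 2 to compound 3 (0.73 log units; beyond the scatter), so the arrangement of this ring matters even though the two groups carry the same atoms. With 4-chlorophenyl held in place, 2,6-dichlorophenyl in place of phenyl on the saturated chain carbon bound to a sulfur gives an at least 7.9-fold higher number from compound 1 to compound 3 (0.89 log units; beyond the scatter), so the second place of change also moves the number once it is read alone, which the first two compounds, differing in both places, could not show. Compound 3 has only a limit of the assay and not a number, so the full size of both steps stays unknown: the limit of > 400000 nM in this assay, at which 1 of the 3 values shown sits.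

The compounds shown leave open what an unsubstituted phenyl or a 4-aminophenyl on that nitrogen would give. They also leave open how plain benzylsulfanyl behaves when paired with 3-chlorophenyl, the one combination that would show whether the two changes act independently of each other.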